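Methoxy for Trifluoromethyl on a Biaryl Sulfonamide

The compounds below may be only part of what the source reports. "The series", "measured", "known", "first", "only" and "open" are said of these compounds alone.

Of the compounds shown here, two have been measured. Compound 1 `CC1CCN(C2CCN(S(=O)(=O)c3sc(Cl)nc3C3CC3)CC2)CC1` is the smaller of the pair. In a functional assay on DLD-1 cells (Homo sapiens) for antiproliferative activity, read by CellTiter-Glo, with a stated time of 72 h (a higher number here means a weaker inhibitor, a lower number a stronger inhibitor), compound 1 gives only a limit, > 5000 nM, and no number. Compound 2 `CC1CCN(C2CCN(S(=O)(=O)c3ccccc3-c3ccc(C(F)(F)F)cc3)CC2)CC1` carries a second aromatic ring bearing a trifluoromethyl group. In this assay, for the measured compounds named here, compound 2 gives 122 nM, the only actual number in the set. Against it stands (the limit of > 5000 nM in this assay, at which 1 of the 2 values shown sits), which belongs to compound 1 alone, so compound 2 cannot be ranked against anything but that limit.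

Compound 3 `COc1ccc(-c2ccccc2S(=O)(=O)N2CCC(N3CCC(C)CC3)CC2)cc1` is the next compound, not yet measured. It differs from compound 2 in one place: methoxy in place of trifluoromethyl on an aromatic carbon. Going by the values given here, no measured pair in this set shows this change, so the data give no guide to its size or direction. The expectation is that the step from compound 2 to compound 3 in this assay, a 2.0-fold higher number from compound 2 to compound 3 (0.31 log units; beyond the scatter), will be a modest weakening that may well fall within the scatter of repeated measurements. Compound 3 is accordingly expected to give about 250 nM in this assay, within a range from 80 nM to 800 nM.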

Compound 3, half-maximal inhibitory concentration: 1000 nM
Compound 3: middle estimate off by 4.0-fold (0.60 log units), on the low side; the whole stated range lies below it.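

In this assay, for the compounds shown here, going from 4-(trifluoromethyl)phenyl to 4-methoxyphenyl gives an 8.2-fold higher number from compound 2 to compound 3 (0.91 log units; beyond the scatter), the first step in the set that can be read from one change in one place. Compound 2 and compound 3 share everything else, so the result shows that the number in this assay responds to the group on this aromatic carbon, para to a large group, and that this change weakens the compound rather than leaving it within the scatter. Nothing measured here speaks to why the swap has this effect, and the one limit on record, which belongs to compound 1, does not bear on it.

With only these two groups compared at this position, the compounds shown leave open whether a chlorine, a nitrile, an ethoxy group or a plain hydrogen there would read closer to compound 2 or to compound 3. They also leave open whether methoxy in place of trifluoromethyl would give a step of similar size and direction on another aromatic carbon of the same ring, or on a different core.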